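Shortening the chain and swapping the amide end group

The compounds below may be only part of what the source reports. "The series", "measured", "known", "first", "only" and "open" are said of these compounds alone.

Measured compounds:
compound 1 `Nc1ncnc2c1c(-c1cnc3[nH]ccc3c1)nn2CCCCCCCCC(=O)NO` gives 9.54 nM
compound 2 `CNC(=O)CCCCCCCn1nc(-c2ccc3oc(N)nc3c2)c2c(N)ncnc21` gives 6.73 nM

Both were tested in an assay on isolated protein for inhibition of protein deacetylase HDAC6 (Homo sapiens), with a stated time of 15 min; a lower number here means a stronger inhibitor, a higher number a weaker inhibitor. Compound 2 gives 6.73 nM in this assay, and compound 1 gives 9.54 nM; the gap between them lies within the usual scatter, so the two read as equally strong inhibitors on these numbers.

Compound 3 `Nc1nc2cc(-c3nn(CCCCCCC(=O)NO)c4ncnc(N)c34)ccc2o1` has not yet been measured in this assay. It differs from compound 2 in one place: hydroxycarbamoyl in place of (methylcarbamoyl)methyl on a saturated chain carbon, six bonds along the chain from an aromatic nitrogen. Among the measured compounds shown here, no measured pair shows this exact change, so the size of its step is unknown. Compound 1 carries a hydroxycarbamoyl end and reads within the scatter of compound 2, which suggests that neither end group decides potency here. For compound 3 a step of a 1.2-fold lower number from compound 2 to compound 3 (0.09 log units; within the scatter) is expected, that is no change beyond the scatter. Compound 3 is therefore estimated at 5.5 nM, with a likely range from 1.8 nM to 17 nM.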

Compound 3, half-maximal inhibitory concentration: 10.3 nM
The estimate for compound 3 lay 1.9-fold (0.27 log units) below the measured number; low and high end bracket the measured number.
By their numbers in this assay, from the lowest: compounds 2, 1 and 3 (each within the scatter of the next).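

Among the compounds shown here, the step of a 1.5-fold higher number from compound 2 to compound 3 (0.18 log units; within the scatter) in this assay is the first direct measure of this change, on a saturated chain carbon, six bonds along the chain from an aromatic nitrogen. On the shared core, then, compound 2 with its methylcarbamoyl end and compound 3 with its hydroxycarbamoyl end read as equally strong inhibitors. The change alters the end group and the chain length together, as the reading 4-(methylcarbamoyl)butyl to 3-(hydroxycarbamoyl)propyl shows, so this one step cannot assign any share to either part.

Still open, as far as these compounds go, is how a longer chain ending in hydroxycarbamoyl would read on this core, and whether a carboxylic acid or a primary amide at the chain end would fit the same picture. Nothing available on these compounds explains the result.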